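The source may hold more compounds than are shown below. What is called first, only, known or untested is meant among the compounds shown, and "the series" means these compounds.

Working notes on the series. Three compounds have so far been run in an assay on isolated protein for displacement of a labelled ligand from 5-hydroxytryptamine receptor 6 (Homo sapiens), read by scintillation counting, with a stated time of 1 h; on this read-out lower numbers stand for stronger inhibition and higher numbers for weaker inhibition. Compound 1 `CC(=O)N1CCN(c2cn(S(=O)(=O)c3ccccc3)c3ccccc23)CC1` gives 97 nM. Compound 2 `O=S(=O)(c1ccccc1)n1cc(N2CCCCC2)c2ccccc21` gives 219 nM. Compound 3 `CC(=O)N1CCN(c2cccc3c2ccn3S(=O)(=O)c2ccccc2)CC1` gives 714 nM, the highest of the three numbers; its gap to compound 2 and its wider gap to compound 1 both lie beyond the scatter.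

Compound 1 and compound 3 are built from the same atoms joined differently; the difference between the two cores is not broken down here.

One change has been measured once. piperidin-1-yl in place of 4-acetylpiperazin-1-yl on an aromatic carbon This made a 2.3-fold higher number from compound 1 to compound 2 (0.35 log units; beyond the scatter).

Compound 4 `O=S(=O)(c1ccccc1)n1ccc2c(N3CCCCC3)cccc21` is not yet measured. It derives from compound 3 as follows. piperidin-1-yl in place of 4-acetylpiperazin-1-yl on an aromatic carbon The leaving and entering groups match those from compound 1 to compound 2, but the place does not: there the carbon belonged to a five-membered aromatic ring with 1 nitrogen, here to a six-membered aromatic ring of carbon only, ortho to a fused ring and meta to a fused ring. It is the same kind of change, not the same change.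

The step from compound 3 to compound 4 is expected to be a 2.2-fold higher number from compound 3 to compound 4 (0.35 log units; beyond the scatter). Going by the values given here, that expectation rests on the single measured step of a 2.3-fold higher number from compound 1 to compound 2 (0.35 log units; beyond the scatter), taken at about its own size, since nothing here shows whether the different place alters it. Among the compounds with values here, compound 4 is accordingly expected to give 1600 nM in this assay, with the range 600 nM to 4500 nM kept wide for the change of place and the single precedent.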

Compound 4, inhibition constant: 128 nM
For compound 4 the middle estimate is 13-fold (1.10 log units) above the measured one, outside the stated range (below it).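

In this assay, the same exchange of 4-acetylpiperazin-1-yl for piperidin-1-yl gave a 5.6-fold lower number from compound 3 to compound 4 (0.75 log units; beyond the scatter), the opposite direction to the earlier step, and the two steps clearly differ: the same change on two cores in this assay, a 2.3-fold higher number (0.35 log units; beyond the scatter) from compound 1 to compound 2 and a 5.6-fold lower number (0.75 log units; beyond the scatter) from compound 3 to compound 4, 13-fold (1.10 log units) apart, beyond the scatter of two such steps This shows that, in this series, the change does not carry from one core to another at a fixed size or even in a fixed direction, so the step on the core of compound 1 gives no usable guide to the step on the core of compound 3. It does not show why the direction reverses, whether the ring carrying the group or some other difference between the cores is responsible, or how general the reversal is, since it rests on a single pair of compounds on each core.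

The compounds shown leave open whether other groups on the same aromatic carbons, such as morpholin-4-yl or piperazin-1-yl with a free ring amine, would split between the two cores in the same way. They also leave open whether the reversal holds for a simple open-chain amine such as dimethylamino, which would test whether it depends on the six-membered ring of the group.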